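A few compounds are considered here, and "the series" means these few. Any claim that something is new, unique, unknown or untested is made for them only; others in the source may bear on it.

Measured so far in an ADME assay on the whole organism with Oryza sativa as the target, tested at 0.1 uM; on this read-out higher numbers stand for a weaker effect at the one concentration tested and lower numbers for a stronger effect:
compound 1 `Cc1ccc(NC(=O)N[C@@H](C)c2ccccc2)cc1`: 100%
compound 2 `C[C@@H](NC(=O)Nc1ccccc1F)c1ccccc1`: 97%
compound 3 `C[C@H](NC(=O)Nc1ccccc1F)c1ccccc1`: 98%

Compound 3 stands second highest of the three numbers, with compound 2 nearest, a number 1 percentage points higher from compound 2 to compound 3 (within the scatter), and compound 1 furthest, both gaps within the scatter, so the three readings are indistinguishable. The pairing of compounds 2 and 3 rests on (the fact that compounds 2 and 3 differ only in the configuration as drawn).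

Compound 4 `Cc1ccc(NC(=O)N[C@@H](C)c2ccccc2)c(F)c1` follows from compound 3 by methyl in place of hydrogen on an aromatic carbon. Among the measured compounds shown here, no measured step covers a methyl; the only measured step, from compound 2 to compound 3, is a configurational change within the scatter. Compound 1, which carries a methyl on an aromatic carbon without a fluoro group, reads at the same level as compound 3 in this assay. No step beyond the scatter is therefore expected. Compound 4 is expected to give 98%, between 90% and 100%, an expected step of no change at the digits printed from compound 3 to compound 4 (within the scatter).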

Compound 4, a percentage reported as activity, at one concentration (the size of the read-out at that concentration, not a potency): 100%
Compound 4: middle estimate off by 2 percentage points, on the low side, and the stated range covers the measured number.
By their numbers in this assay, from the lowest: compounds 2, 3, 1 and 4 (each within the scatter of the next).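

In this assay, methyl in place of hydrogen on an aromatic carbon, meta to a fluoro group and para to a large group, gives a number 2 percentage points higher from compound 3 to compound 4 (within the scatter), while adding a fluoro group gives no change at the digits printed from compound 1 to compound 4 (within the scatter). Neither single change on the aromatic ring moves the reading beyond the scatter, so the methyl and the fluoro group cannot be told apart at this one concentration. Nothing on hand bears on either of these two changes.

Going by these compounds, whether an amine or a carboxylic acid on this aromatic carbon would shift the reading remains open. So does whether any change to the shared core departs from this level.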